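The source may hold more compounds than are shown below. What is called first, only, known or untested is meant among the compounds shown, and "the series" means these compounds.

Compound 2 `C/C(=N\C(C)C)c1c(O)c2ccccc2[nH]c1=O` is the starting point of this step. In an assay on isolated protein for inhibition of myosin-2 (Bos taurus), read by spectrophotometry, with a stated time of 24 min (on this read-out higher numbers stand for weaker inhibition and lower numbers for stronger inhibition), compound 2 gives >= 100000 nM, which is a limit of the measurement rather than a number. It shares this position with one other compound, since (the limit of >= 100000 nM in this assay, at which 2 of the 3 values shown sit). Compound 1 `C/C(=N\CC(C)C)c1c(O)c2ccccc2oc1=O` differs from compound 2 both in its core and in carrying an isobutyl group on the double-bonded nitrogen; in this assay compound 1 gives 34000 nM. Compound 3 `C/C(=N\Cc1ccccc1C)c1c(O)c2ccccc2oc1=O` differs from compound 1 in that group alone. In this assay compound 3 gives >= 100000 nM, again a limit. For the measured compounds named here, the only measured step that alters the group on that nitrogen is an at least 2.9-fold higher number from compound 1 to compound 3 (0.46 log units; beyond the scatter), so changing this group has so far moved the number only toward weaker inhibition. Going by the values given here, compound 4 `C/C(=N\CC(C)C)c1c(O)c2ccccc2[nH]c1=O` is the compound not yet measured. isobutyl in place of isopropyl on a double-bonded nitrogen This change is smaller than the one seen in compound 3, and it places the isobutyl group of compound 1 on the core of compound 2. Among the compounds with values here, no measured step joins compound 1 to compound 4, so the values of compound 1 and compound 2 bracket what can be expected. Compound 4 is therefore expected to give about 100000 nM in this assay, between 30000 nM and 300000 nM, quite possibly again only as a limit. The step from compound 2 to compound 4 is expected to be a number no higher from compound 2 to compound 4 (the limit leaves the size open).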

Compound 4, half-maximal inhibitory concentration: >= 100000 nM
Compound 4 was reported as a limit; the forecaster's own chance of this, stated with the estimate: 60%; the middle value sits exactly at the limit.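

Compound 2 and compound 4 both sit at the same limit of the measurement, not at a number, so no step between them can be read: the limit of >= 100000 nM in this assay, at which 3 of the 4 values shown sit.

The compounds shown leave open how strongly either compound inhibits, and whether isobutyl in place of isopropyl on the core of compound 2 changes the number at all.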